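Halogen moved on the indole: a value still to come

The compounds below may be only part of what the source reports. "The series", "measured", "known", "first", "only" and "open" are said of these compounds alone.

compound 1 `COc1ccc2[nH]c(C(=O)NCCCN3CCN(c4ccccc4OC)CC3)cc2c1` — 77.6 nM
compound 2 `COc1ccccc1N1CCN(CCCNC(=O)c2cc3ccc(Br)cc3[nH]2)CC1` — 69.2 nM

In an assay on isolated protein (Vas deferens, strain Sprague-Dawley) for antagonist activity at Alpha-1A adrenergic receptor (Rattus norvegicus), with a stated time of 20 min (on this read-out lower numbers stand for tighter binding and higher numbers for weaker binding), compound 1 gives 77.6 nM and compound 2 gives 69.2 nM. These two numbers lie within the usual scatter of each other, so compound 2 is not separated from compound 1 on this read-out. Compound 3 `COc1ccccc1N1CCN(CCCNC(=O)c2cc3cc(Cl)ccc3[nH]2)CC1` differs from compound 2 in one place: 5-chloro-1H-indol-2-yl in place of 6-bromo-1H-indol-2-yl on a carbonyl carbon. Among the compounds with values here, no measured pair shows a step for this kind of change, so the expectation rests on the two values, which agree closely. The expected step is a 1.0-fold higher number from compound 2 to compound 3 (0.00 log units; within the scatter), none beyond the scatter. Compound 3 is estimated at 70 nM, within 30 nM to 160 nM.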

Compound 3, dissociation constant: 47.9 nM
Compound 3: middle estimate off by 1.5-fold (0.16 log units), on the high side, and the stated range covers the measured number.
By their numbers in this assay, from the lowest: compounds 3, 2 and 1 (each within the scatter of the next).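

In this assay, 5-chloro-1H-indol-2-yl in place of 6-bromo-1H-indol-2-yl on a carbonyl carbon gives a 1.4-fold lower number from compound 2 to compound 3 (0.16 log units; within the scatter), so this change does not separate compound 3 from compound 2. Chloro in place of methoxy on an aromatic carbon gives a 1.6-fold lower number from compound 1 to compound 3 (0.21 log units; within the scatter), so these three substituents are not told apart on this read-out. No measurement offered here accounts for these numbers.

Compound 2 and compound 3 differ in both halogen and its place, so neither can be judged alone. From the compounds shown here alone, whether an amine or a carboxylic acid in place of chloro in compound 3 would move the number beyond the scatter remains open.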